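Benzimidazole replaces the aminoimidazolone on the ether chain

The compounds below may be only part of what the source reports. "The series", "measured", "known", "first", "only" and "open" are said of these compounds alone.

Compound 3 `CCO/C(O)=C1\C(COCCN2CC(=O)N=C2N)=NC(C)=C(C(=O)OC)C1c1ccccc1Cl` gives 20 nM in a functional assay (aorta) with Rattus norvegicus as the target; on this read-out lower numbers stand for stronger inhibition and higher numbers for weaker inhibition. Compound 1 `CCO/C(O)=C1\C(COCCn2cc(N)n(C)c2=O)=NC(C)=C(C(=O)OC)C1c1ccccc1Cl` gives 25.1 nM, and the two lie within the scatter of each other. Compound 2 `CCO/C(O)=C1\C(COCCn2ccnc2C)=NC(C)=C(C(=O)OC)C1c1ccccc1Cl` gives 2.51 nM; the step of an 8.0-fold higher number from compound 2 to compound 3 (0.90 log units; beyond the scatter) and the step of a 10-fold lower number from compound 1 to compound 2 (1.00 log units; beyond the scatter) are the only ones in this assay beyond the scatter. Compound 4 `CCO/C(O)=C1\C(COCCn2cnc3ccccc32)=NC(C)=C(C(=O)OC)C1c1ccccc1Cl` carries a group of 9 heavy atoms (7 carbon, 2 nitrogen; one five-membered aromatic ring with 2 hetero atoms, one six-membered aromatic ring of carbon only) in place of a group of 7 heavy atoms (3 carbon, 3 nitrogen, 1 oxygen; one five-membered non-aromatic ring with 2 hetero atoms), on a saturated chain carbon, two bonds along the chain from an oxygen on a saturated carbon. Both steps bear on it, since each exchanges the group on this chain carbon, and in each the five-membered aromatic ring with 2 hetero atoms gave the lower number. 1H-benzimidazol-1-yl shares that ring with compound 2, so a modest step down is expected, a 4.4-fold lower number from compound 3 to compound 4 (0.65 log units; beyond the scatter). Compound 4 is therefore expected at 4.5 nM, with a range of 1.5 nM to 14 nM.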

Compound 4, half-maximal inhibitory concentration: 20 nM
For compound 4 the middle estimate is 4.4-fold (0.65 log units) below the measured one; measured number outside the range, above it.
By their numbers in this assay, from the lowest: compound 2; then compounds 3, 4 and 1 (each within the scatter of the next).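

In this assay, a five-membered aromatic ring with 2 hetero atoms on this chain carbon does not by itself give the low number: 1H-benzimidazol-1-yl shows no change at the digits printed from compound 3 to compound 4 (within the scatter) and a 1.3-fold lower number from compound 1 to compound 4 (0.10 log units; within the scatter). Only 2-methyl-1H-imidazol-1-yl stands apart, with an 8.0-fold higher number from compound 2 to compound 4 (0.90 log units; beyond the scatter), so the earlier link between that ring type and a lower number does not hold for compound 4. No measured evidence accounts for this.

The step to 1H-benzimidazol-1-yl both removes the methyl and adds a six-membered aromatic ring of carbon only, so the two changes remain unseparated. 1H-imidazol-1-yl and 2-methyl-1H-benzimidazol-1-yl would each isolate one of them.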